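This account rests on a few compounds, and the source may have more. Where it says the series, first, only, none or still open, it means among the compounds named here.

- Compound 1 `COc1cccc(NC2=CC(=O)c3ncncc3C2=O)c1`: 1800 nM
- Compound 2 `O=C1C(Nc2cccc(B(O)O)c2)=CC(=O)c2ncncc21`: > 10000 nM
- Compound 3 `CCOC(=O)c1ccc(NC2=CC(=O)c3ncncc3C2=O)cc1`: 5900 nM

In a functional assay on BXPC-3 cells (Homo sapiens) for cytotoxicity, read by MTT assay, with a stated time of 72 h (on this read-out lower numbers stand for stronger inhibition and higher numbers for weaker inhibition), compound 2 reads > 10000 nM, which is a limit and not a number. This is the limit of > 10000 nM in this assay, at which 1 of the 3 values shown sits.

Compound 4 `CC(=O)c1cccc(NC2=CC(=O)c3ncncc3C2=O)c1` differs from compound 2 by one change: a group of 3 heavy atoms (2 carbon, 1 oxygen; no ring) in place of a group of 3 heavy atoms (1 boron, 2 oxygen; no ring), on an aromatic carbon. For the measured compounds named here, the one measured step bearing on this swap is an at least 5.5-fold higher number from compound 1 to compound 2 (0.74 log units; beyond the scatter). It shows that changing the group on this aromatic carbon can move the number beyond the scatter. Compound 1 gives 1800 nM, and compound 3 gives 5900 nM. With an acetyl group in place, a lower number is expected, and the estimated step is an at least 3.3-fold lower number from compound 2 to compound 4 (0.52 log units; beyond the scatter). For compound 4 the expected value is 3000 nM, with an estimated range of 1000 nM to 10000 nM.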

Compound 4, half-maximal inhibitory concentration: 5200 nM
Beside the measured number, compound 4's estimate is 1.7-fold (0.24 log units) below it; low and high end bracket the measured number.
By their numbers in this assay, from the lowest: compound 1; then compounds 4 and 3 (each within the scatter of the next). At a limit, above all of these: compound 2.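

In this assay, acetyl in place of methoxy gives a 2.9-fold higher number from compound 1 to compound 4 (0.46 log units; beyond the scatter), so two groups on this aromatic carbon can now be compared by actual numbers. Against the group of boron and two oxygens, the result is only a floor, an at least 1.9-fold lower number from compound 2 to compound 4 (0.28 log units; that floor lies within the scatter), and so does not show that acetyl reads better than that group. Compound 2 remains a limit and not a number: the limit of > 10000 nM in this assay, at which 1 of the 4 values shown sits.

The compounds shown leave open how an amine or a carboxylic acid would read on this aromatic carbon. They also leave open how acetyl would read elsewhere on this ring.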